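Permeability notes on a nitrile-bearing tricyclic series

The source may hold more compounds than are shown below. What is called first, only, known or untested is meant among the compounds shown, and "the series" means these compounds.

Two compounds of the shared core have been run in an ADME assay on Caco-2 cells (Homo sapiens) for permeability, in the apical to basolateral direction; a higher number here means that the compound crosses the layer faster, a lower number that the compound crosses the layer more slowly. Compound 1 `Cn1cncc1CN1CC(N(CC2CCN(C(=O)N3CCCCC3)CC2)S(=O)(=O)c2ccccn2)Cc2cc(C#N)ccc21` gives 0.6 10^-6 cm/s in this assay. Compound 2 `Cn1cnc(S(=O)(=O)N(Cc2cccc(-n3cccc3)c2)C2Cc3cc(C#N)ccc3N(Cc3cncn3C)C2)c1` gives 0.2 10^-6 cm/s in this assay. Compound 1 stands highest of the two numbers; the nearest, compound 2, sits a good deal lower, and that gap lies beyond the usual scatter. Within the data shown here, no pair of measured compounds differs in a single place, so no step within the measured set can be read off.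

Compound 3 `CC(C)C(=O)N1CCC(CN(C2Cc3cc(C#N)ccc3N(Cc3cncn3C)C2)S(=O)(=O)c2ccccn2)CC1` is not yet measured. It differs from compound 1 in one place: isopropyl in place of piperidin-1-yl on a carbonyl carbon.

Among the measured compounds shown here, no measured step covers this change, and with only two measured compounds nothing further can be drawn from them. The step from compound 1 to compound 3 in this assay is therefore expected to be small, a 1.3-fold higher number from compound 1 to compound 3 (0.12 log units; within the scatter), within the scatter. Compound 3 is expected to give about 0.8 10^-6 cm/s in this assay, in the range 0.3 10^-6 cm/s to 2 10^-6 cm/s.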

Compound 3, apparent permeability: 0.5 10^-6 cm/s
Compound 3: middle estimate off by 1.6-fold (0.20 log units), on the high side; measured number inside the range.
By their numbers in this assay, from the lowest: compound 2; then compounds 3 and 1 (each within the scatter of the next).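

Among these compounds, on the carbonyl carbon, isopropyl in place of piperidin-1-yl gives the first step that can be read: in this assay it amounts to a 1.2-fold lower number from compound 1 to compound 3 (0.08 log units; within the scatter) and so leaves the two compounds level. For this one pair, then, a group with no ring and 3 heavy atoms can stand where a six-membered non-aromatic ring with 6 heavy atoms stood without the number moving beyond the scatter. Nothing at hand bears on the reason for this result.

Going by these compounds, whether an amine or a carboxylic acid on the group at this carbonyl carbon would move the number beyond the scatter remains open, as does the effect of a longer chain there. Among the compounds shown here, compound 2 differs from the others in more than one place, so no step to it can be read.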